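Benzyl substituent change on the shared core

A few compounds are considered here, and "the series" means these few. Any claim that something is new, unique, unknown or untested is made for them only; others in the source may bear on it.

Measured compounds:
compound 1 `CCCCNc1nc(N)nc2c1CN(Cc1c(Cl)cccc1Cl)CC2` gives 0.14 uM in an assay on HEK293 cells for agonist activity at Toll-like receptor 8 (Homo sapiens), read by a luciferase reporter, with a stated time of 6 h; a lower number here means that less compound is needed, a higher number that more compound is needed for the effect
compound 2 `CCCCNc1nc(N)nc2c1CN(Cc1ccc(OC)cc1)CC2` gives 0.08 uM in this assay

For the measured compounds named here, compound 2 shows the lowest of the two numbers in this assay, but its only neighbour is compound 1, and the step of a 1.8-fold lower number from compound 1 to compound 2 (0.24 log units; within the scatter) is within the scatter, so the two compounds cannot be placed in order on these data.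

Compound 3 `CCCCNc1nc(N)nc2c1CN(Cc1ccc(C(F)(F)F)cc1)CC2` differs from compound 2 in one place: trifluoromethyl in place of methoxy on an aromatic carbon. Going by the values given here, no measured step covers this exchange. Among the compounds with values here, the single step on record, a 1.8-fold lower number from compound 1 to compound 2 (0.24 log units; within the scatter), changes the whole aryl group on the saturated chain carbon and is within the scatter; it only shows that a change at this part of the molecule has so far moved the minimum effective concentration little. On that basis no step beyond the scatter is expected in this assay in either direction, and the range is widened for the lack of a direct precedent.

Compound 3 is therefore estimated at 0.1 uM, with a range from 0.04 uM to 0.3 uM. The expected step is a 1.3-fold higher number from compound 2 to compound 3 (0.10 log units; within the scatter), which would remain within the scatter.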

Compound 3, minimum effective concentration: 0.23 uM
The estimate for compound 3 lay 2.3-fold (0.36 log units) below the measured number; the range from low to high includes it.
By their numbers in this assay, from the lowest: compounds 2, 1 and 3 (each within the scatter of the next, the first and the last beyond it).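

In this assay, for the compounds shown here, the exchange of methoxy for trifluoromethyl on the aromatic carbon para to a large group brings a 2.9-fold higher number from compound 2 to compound 3 (0.46 log units; beyond the scatter) and is the first step to lie beyond the scatter. The minimum effective concentration thus responds, if only modestly, to the group at this position, so more compound is needed with trifluoromethyl than with methoxy, whereas the earlier step of a 1.8-fold lower number from compound 1 to compound 2 (0.24 log units; within the scatter) changed the whole aryl group and could not be read as a difference. The data at hand offer nothing that accounts for this step, so it stands as an observation on one matched pair.

Going by these compounds alone, what remains open is whether methoxy is favoured in its own right or trifluoromethyl is disfavoured, since this single pair gives no reference compound with an unsubstituted aromatic carbon at this position. A hydrogen, a hydroxyl, a nitrile, a dimethylamino group or a carboxylic acid on the same carbon would show whether the minimum effective concentration follows a trend across groups or whether this step is particular to these two.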